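Swapping a phenylethyl for a cyclohexyl on the urea nitrogen

The source may hold more compounds than are shown below. What is called first, only, known or untested is meant among the compounds shown, and "the series" means these compounds.

Measured so far:
compound 1, `Cc1nc(N)sc1CCCN/C(N)=N/C(=O)NC(C)c1ccc(Br)cc1`, 30.2 nM
compound 2, `Cc1nc(N)sc1CCCN/C(N)=N/C(=O)N[C@@H](C)c1ccccc1`, 51.3 nM

Both compounds were tested in an assay on membranes from Sf9 cells for displacement of a labelled ligand from histamine H2 receptor (Homo sapiens), read by scintillation counting, with a stated time of 60 min; a lower number here means a stronger inhibitor, a higher number a weaker inhibitor. Compound 1 gives 30.2 nM. Compound 2 gives 51.3 nM. These two numbers sit close together, and the gap between them is within the usual scatter of repeated measurements, so neither compound can be called the stronger or the weaker binder on this evidence. Compound 2 is simply the second of two closely matched points.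

The next compound, compound 3 `Cc1nc(N)sc1CCCN/C(N)=N/C(=O)NC1CCCCC1`, has not yet been measured in this assay. It differs from compound 2 in one place: cyclohexyl in place of 1-phenylethyl on an amide-type nitrogen. Within the data shown here, no measured pair shows what this kind of exchange does in this assay, so there is no step to lean on. Among the measured compounds shown here, with only two close values in hand, a modest change in either direction, or none beyond the scatter, seems the fair expectation. The estimate for compound 3 in this assay is 80 nM, with a range from 25 nM to 300 nM. That estimate corresponds to an expected step of a 1.6-fold higher number from compound 2 to compound 3 (0.19 log units; within the scatter), which is still only slightly beyond the scatter.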

Compound 3, inhibition constant: 170 nM
For compound 3 the middle estimate is 2.1-fold (0.33 log units) below the measured one, within the range that was stated.
By their numbers in this assay, from the lowest: compounds 1 and 2 (each within the scatter of the next); then compound 3.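

In this assay, among these compounds, a 3.3-fold higher number from compound 2 to compound 3 (0.52 log units; beyond the scatter) is the first step in this set that lies beyond the scatter, which shows that the group on the amide-type nitrogen does affect the number, though only modestly. This one exchange changes several things at once: a six-membered aromatic ring of carbon only gives way to a six-membered non-aromatic ring of carbon only, the group goes from 8 heavy atoms to 6, and the defined stereocentre is lost, while neither group carries any hydrogen-bond donors or acceptors. No measurement of any property of these groups comes with the result, so what lies behind the step remains unknown.

The compounds shown leave open which of those three differences accounts for the step. A 1-cyclohexylethyl group on the same nitrogen would keep the branched carbon of 1-phenylethyl and change only the ring, so it could begin to separate the loss of the aromatic ring from the loss of size and of the stereocentre.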